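The compounds below may be only part of what the source reports. "The series", "measured", "known", "first", "only" and "open" are said of these compounds alone.

Working notes on the series. In a toxicity assay on MT4 cells (Homo sapiens) for cytotoxicity, read by MTT assay (on this read-out lower numbers stand for higher toxicity in this test and higher numbers for lower toxicity in this test), compound 1 `Cc1cc(-c2ccccc2)cc(C)c1Oc1cc(N)nc(Nc2ccc(C#N)cc2)n1` gives 25600 nM, compound 2 `Cc1cc(-c2ccccc2C#N)cc(C)c1Oc1cc(N)nc(Nc2ccc(C#N)cc2)n1` gives 25400 nM and compound 3 `Cc1cc(-c2ccccc2)ccc1Oc1cc(N)nc(Nc2ccc(C#N)cc2)n1` gives 20000 nM. Compound 3 therefore stands level with the other two, as its gaps to both lie within the scatter. All three numbers fall in one narrow band.

Next in line is compound 4 `Cc1cc(-c2ccc(C#N)cc2)ccc1Oc1cc(N)nc(Nc2ccc(C#N)cc2)n1`, which differs from compound 3 by cyano in place of hydrogen on an aromatic carbon, para to a large group, read further out as phenyl to 4-cyanophenyl: cyano in place of hydrogen on an aromatic carbon.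

Among the compounds with values here, two measured steps bear on this. Within the data shown here, the closest precedent, also cyano in place of hydrogen on an aromatic carbon, is a 1.0-fold lower number from compound 1 to compound 2 (0.00 log units; within the scatter). It differs in two ways: the cyano sits on another carbon, and the core of compound 1 keeps the methyl that compound 3 lacks. The second, hydrogen in place of methyl on an aromatic carbon, is a 1.3-fold lower number from compound 1 to compound 3 (0.11 log units; within the scatter), which shows that this methyl difference left the number within the scatter.

Neither step points in a clear direction, so no step beyond the scatter is expected in this assay. The estimated change is a 1.1-fold lower number from compound 3 to compound 4 (0.05 log units; within the scatter). For compound 4 the estimated value is 18000 nM, with an expected range from 8000 nM to 32000 nM.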

Compound 4, half-maximal cytotoxic concentration: 10400 nM
For compound 4 the middle estimate is 1.7-fold (0.24 log units) above the measured one; the range from low to high includes it.
By their numbers in this assay, from the lowest: compounds 4, 3, 2 and 1 (each within the scatter of the next, the first and the last beyond it).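

Within the data shown here, compound 4 is the first case here with cyano on the carbon para to a large group, and in this assay this change gives a 1.9-fold lower number from compound 3 to compound 4 (0.28 log units; within the scatter). This position therefore takes the nitrile without a step beyond the scatter, just as the different carbon carrying it in compound 2 did. Although the two steps differ in both the carbon bearing the cyano and the core, they can be read as agreeing: the same change on two cores in this assay, a 1.0-fold lower number (0.00 log units; within the scatter) from compound 1 to compound 2 and a 1.9-fold lower number (0.28 log units; within the scatter) from compound 3 to compound 4, 1.9-fold (0.28 log units) apart, within the scatter of two such steps

Among these compounds, whether an amine, a carboxylic acid or a longer chain at this position would also stay within the scatter remains open, since the only change seen here is hydrogen to cyano. Also open, on these data alone, is how 4-cyanophenyl would read on the core of compound 1, so the effects of the cyano position and the core methyl on the comparison of these two steps cannot yet be separated.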